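The compounds below may be only part of what the source reports. "The series", "measured", "known", "first", "only" and "open" are said of these compounds alone.

In a functional assay on A375P cells (Homo sapiens) for cytotoxicity, read by MTT assay, with a stated time of 2 days (on this read-out higher numbers stand for weaker inhibition and lower numbers for stronger inhibition), compound 3, `Cc1cccc(N2CCN(CCCNc3nc(NCc4ccco4)c4cc(F)ccc4n3)CC2)c1C`, gives 2830 nM, and compound 1, `Cc1cccc(N2CCN(CCCNc3nc(NCc4ccco4)c4ccccc4n3)CC2)c1C`, gives 3040 nM. The change between them, (hydrogen in place of fluoro on an aromatic carbon), produced a 1.1-fold higher number from compound 3 to compound 1 (0.03 log units; within the scatter). Compound 2, `Fc1ccc2nc(NCCCCN3CCN(c4cccc(Cl)c4Cl)CC3)nc(NCc3ccco3)c2c1`, gives 2650 nM in this assay; how its core differs from the core of compound 3 is not broken down here. Compound 4, `Clc1cccc(N2CCN(CCCCNc3nc(NCc4ccco4)c4ccccc4n3)CC2)c1Cl`, remains to be measured. It differs from compound 2 by hydrogen in place of fluoro on an aromatic carbon, the same kind of change as that made from compound 3 to compound 1, here on the core of compound 2. The step expected in this assay is a 1.1-fold higher number from compound 2 to compound 4 (0.04 log units; within the scatter), set beside the earlier step, because the earlier change gave only a 1.1-fold higher number from compound 3 to compound 1 (0.03 log units; within the scatter) and nothing among these compounds suggests a different outcome. For compound 4 the estimate is 2900 nM, with a likely range from 1500 nM to 5600 nM.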

Compound 4, half-maximal inhibitory concentration: 3750 nM
Compound 4: the middle estimate sits 1.3-fold (0.11 log units) below what was measured; the measured number falls inside the stated range.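

In this assay, hydrogen in place of fluoro on the core of compound 2 gave a 1.4-fold higher number from compound 2 to compound 4 (0.15 log units; within the scatter). Set beside the same change on the other core, the two steps do not differ: the same change on two cores in this assay, a 1.1-fold higher number (0.03 log units; within the scatter) from compound 3 to compound 1 and a 1.4-fold higher number (0.15 log units; within the scatter) from compound 2 to compound 4, 1.3-fold (0.12 log units) apart, within the scatter of two such steps On these two cores, then, the change carries over with no step beyond the scatter, but two pairs in a single assay do not show that it would stay this small on other cores of the series.

As far as these compounds go, what a methoxy or a nitrile on that aromatic carbon would give in this assay remains open. From the compounds shown here alone, it is also open whether the change would behave the same way on a core with a longer chain.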